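Ring Swap with Added Chlorine: Expectation for Compound 3

This account rests on a few compounds, and the source may have more. Where it says the series, first, only, none or still open, it means among the compounds named here.

Going by the values given here, compound 2 `COc1cc(CSc2cc(Cl)c(-c3nnc(-c4ccccc4)s3)cc2S(=O)(=O)NC(=N)NO)cc(OC)c1OC` gives 2400 nM in a functional assay on SF-268 cells (Homo sapiens) (a lower number here means a stronger inhibitor of growth, a higher number a weaker inhibitor of growth), the lowest of the two numbers known; compound 1 `COc1cc(CSc2cc(Cl)c(-c3nc(-c4ccccc4)no3)cc2S(=O)(=O)NC(=N)NO)cc(OC)c1OC` gives 6920 nM. Among the compounds with values here, the single measured step, a 2.9-fold lower number from compound 1 to compound 2 (0.46 log units; beyond the scatter), is the only guide. Compound 3 `COc1cc(CSc2cc(Cl)c(-c3nc(-c4ccc(Cl)cc4)no3)cc2S(=O)(=O)NC(=N)NO)cc(OC)c1OC` differs from compound 2 by 3-(4-chlorophenyl)-1,2,4-oxadiazol-5-yl in place of 5-phenyl-1,3,4-thiadiazol-2-yl on an aromatic carbon, bringing back the 1,2,4-oxadiazol-5-yl ring seen in compound 1 while the entering group carries a chlorine. Reversing the measured step points to a higher number; the chlorine contributes no known step. Compound 3 is therefore expected to give 5000 nM, within 2000 nM to 15000 nM. The expected step is a 2.1-fold higher number from compound 2 to compound 3 (0.32 log units; beyond the scatter).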

Compound 3, concentration for 50% growth inhibition: 2950 nM
Estimate against measurement, compound 3: 1.7-fold (0.23 log units) above; the measured number falls inside the stated range.
By their numbers in this assay, from the lowest: compounds 2 and 3 (each within the scatter of the next); then compound 1.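

Placing a chlorine on the phenyl ring, which turns 3-phenyl-1,2,4-oxadiazol-5-yl into 3-(4-chlorophenyl)-1,2,4-oxadiazol-5-yl, gives a 2.3-fold lower number from compound 1 to compound 3 (0.37 log units; beyond the scatter) in this assay. This group can therefore be tuned through its six-membered ring, not only through its five-membered ring. Exchanging 5-phenyl-1,3,4-thiadiazol-2-yl for the chlorinated group gives a 1.2-fold higher number from compound 2 to compound 3 (0.09 log units; within the scatter), so these two groups cannot be told apart here.

From the compounds shown here alone, whether a chlorine would act alike on 5-phenyl-1,3,4-thiadiazol-2-yl, or a methoxy group or an amine would match it on the phenyl ring, stays open. Nothing measured here explains the chlorine step.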